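Working notes on four analogues sharing one core

The compounds below may be only part of what the source reports. "The series", "measured", "known", "first", "only" and "open" are said of these compounds alone.

Measured so far:
compound 1, `CC1=C(C(=O)Nc2ccccc2)C(c2cn(-c3ccccc3)nc2-c2ccccc2)NC(=O)N1`: 80600 nM
compound 2, `CC1=C(C(=O)Nc2ccc(C)cc2)C(c2cn(-c3ccccc3)nc2-c2ccccc2)NC(=O)N1`: 71700 nM
compound 3, `CC1=C(C(=O)Nc2ccc([N+](=O)[O-])cc2)C(c2cn(-c3ccccc3)nc2-c2ccccc2)NC(=O)N1`: 35500 nM

In a functional assay on MCF7 cells (Homo sapiens) for inhibition, read by sulforhodamine B assay, with a stated time of 24 h (a lower number here means a stronger inhibitor of growth, a higher number a weaker inhibitor of growth), compound 1 gives the highest of the three numbers. The step of a 1.1-fold lower number from compound 1 to compound 2 (0.05 log units; within the scatter) stays within the scatter, whereas a 2.3-fold lower number from compound 1 to compound 3 (0.36 log units; beyond the scatter) and a 2.0-fold lower number from compound 2 to compound 3 (0.31 log units; beyond the scatter) are modest but beyond it. All three measured changes sit on the anilide phenyl.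

Compound 4, `CC1=C(C(=O)Nc2ccccc2)C(c2cn(-c3ccccc3)nc2-c2ccc(Cl)cc2)NC(=O)N1`, differs from compound 1 by chloro in place of hydrogen on an aromatic carbon. Cut one bond further out, this reads phenyl to 4-chlorophenyl, on the phenyl attached to the pyrazole rather than the anilide. Within the data shown here, no measured step touches that ring, so the anilide steps bear on it only loosely; the closest analogy, a small substituent giving at most a modest lower number, suggests a step of similar or smaller size.

For compound 4 the expected step is a 1.5-fold lower number from compound 1 to compound 4 (0.17 log units; within the scatter). Compound 4 is therefore estimated at 55000 nM, within 25000 nM to 120000 nM.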

Compound 4, concentration for 50% growth inhibition: 65500 nM
Compound 4: the middle estimate sits 1.2-fold (0.08 log units) below what was measured; measured number inside the range.
By their numbers in this assay, from the lowest: compounds 3, 4, 2 and 1 (each within the scatter of the next, the first and the last beyond it).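

Among these compounds, the change from phenyl to 4-chlorophenyl in this assay gives a 1.2-fold lower number from compound 1 to compound 4 (0.09 log units; within the scatter) and is the first reading outside the anilide phenyl. A single chloro at this position, para to a large group, does not separate compound 4 from compound 1, so this ring has shown no step beyond the scatter. No evidence at hand bears on this result. Still open, from the compounds shown here alone, is whether an amine, a carboxylic acid or a methoxy group on this ring would move the number beyond the scatter, and whether chloro here would combine with nitro on the anilide phenyl.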